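Hydroxy for Fluoro on a Chromene-Type Chalcone Scaffold

This account rests on a few compounds, and the source may have more. Where it says the series, first, only, none or still open, it means among the compounds named here.

Compound 1 `COc1ccc(C(=O)/C=C/c2cc(OC)c(OC)c(OC)c2)c2c1C=CC(C)(C)O2` and compound 2 `COc1ccc(C(=O)/C=C/c2cccc(F)c2)c2c1C=CC(C)(C)O2` share the same core and differ only in the aromatic ring attached to it. In a functional assay on K562 cells (Homo sapiens) for antiproliferative activity, read by MTT assay, with a stated time of 24 h (a higher number here means a weaker inhibitor, a lower number a stronger inhibitor), compound 1 gives > 10000 nM, which is a limit of the assay and not a number. In this assay compound 2 likewise gives > 10000 nM, again a limit rather than a measured number. Compound 2 therefore stands at the limit of > 10000 nM in this assay, at which 2 of the 2 values shown sit, and nothing in the data separates it from compound 1; no measured step between any two compounds is given, so no size or direction of change can be read from what is shown.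

Compound 3 `COc1ccc(C(=O)/C=C/c2cccc(O)c2)c2c1C=CC(C)(C)O2` differs from compound 2 by hydroxy in place of fluoro on an aromatic carbon. With both measured values sitting at a limit, the step to compound 3 in this assay can only be expected, not derived. The step that this estimate implies, a step that the limit leaves unreadable from compound 2 to compound 3, is expected to be small, not clearly beyond the usual scatter. Compound 3 is expected to give about 12000 nM in this assay, with a likely range from 2500 nM to 50000 nM.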

Compound 3, half-maximal inhibitory concentration: > 10000 nM
Compound 3: only a limit was reported; the forecaster's own chance of this, stated with the estimate: 65%; the middle value is on the limit's open side.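

Compound 3 gives > 10000 nM in this assay, a limit of the assay and not a number. No step can be read from compound 2 to compound 3, so hydroxy in place of fluoro shows neither size nor direction here: the limit of > 10000 nM in this assay, at which 3 of the 3 values shown sit.

The compounds shown leave open how strongly any of the three acts in this assay, and what this exchange does to that value.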